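The source may hold more compounds than are shown below. What is called first, only, known or untested is meant among the compounds shown, and "the series" means these compounds.

Compounds 1, 2 and 3 share one core and differ in the ring carried on an aromatic carbon. In a functional assay on CWR22R cells (Homo sapiens) for antiproliferative activity, read by CCK-8 assay, with a stated time of 6 days (on this read-out higher numbers stand for weaker inhibition and lower numbers for stronger inhibition), compound 1 (`CCN(c1ccc(C#N)c(Cl)c1)c1cc(-c2ccncc2)ccc1C`), with pyridin-4-yl, gives 1030 nM, and compound 2 (`CCN(c1ccc(C#N)c(Cl)c1)c1cc(-c2cccs2)ccc1C`), with thiophen-2-yl, gives 22000 nM. Compound 3 (`CCN(c1ccc(C#N)c(Cl)c1)c1cc(C2=CCCCC2)ccc1C`), with cyclohex-1-en-1-yl, has no place on this scale, since its result reads "not determined" (no result reported).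

The compound awaiting measurement is compound 4 (`CCN(c1ccc(C#N)c(Cl)c1)c1cc(-c2c[nH]nc2C)ccc1C`). It carries 3-methyl-1H-pyrazol-4-yl in place of cyclohex-1-en-1-yl on the same aromatic carbon: 3-methyl-1H-pyrazol-4-yl in place of cyclohex-1-en-1-yl on an aromatic carbon.

Within the data shown here, only one measured step offers any guidance: a 21-fold higher number from compound 1 to compound 2 (1.33 log units; beyond the scatter). This large step shows that exchanging one ring for another at this carbon can move the number a long way. It involves neither compound 3 nor compound 4, however, and without a number for compound 3, no size or direction can be expected for this change.

Compound 4 is better judged against the two measured neighbours. Its ring is five-membered like the thiophen-2-yl ring and contains nitrogen like the pyridin-4-yl ring, so a result nearer compound 1 at 1030 nM is expected, though with wide uncertainty. For compound 4 the estimated value is 1500 nM, with an expected range from 150 nM to 12000 nM.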

Compound 4, half-maximal inhibitory concentration: 5380 nM
Compound 4: middle estimate off by 3.6-fold (0.55 log units), on the low side; the range from low to high includes it.
By their numbers in this assay, from the lowest: compound 1; then compound 4; then compound 2.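

In this assay, 3-methyl-1H-pyrazol-4-yl places compound 4 between the two rings already measured on this aromatic carbon, with a 4.1-fold lower number from compound 2 to compound 4 (0.61 log units; beyond the scatter) and a 5.2-fold higher number from compound 1 to compound 4 (0.72 log units; beyond the scatter) as its two steps, both beyond the usual scatter. Compound 2 and compound 4 both carry a five-membered aromatic ring at this carbon yet still differ clearly, so ring size alone does not set the number in these compounds, while pyridin-4-yl in compound 1 keeps the lowest number of the three. No measurement is available here that would explain these differences.

The steps involving compound 3 cannot be read, so the compounds shown leave open how a non-aromatic ring such as cyclohex-1-en-1-yl compares with 3-methyl-1H-pyrazol-4-yl at this carbon. Also open, from the compounds shown here alone, is what would happen with the 3-methyl-1H-pyrazol-4-yl ring stripped of its methyl group, with an amine or a carboxylic acid attached to the ring, or with a longer chain in place of the ring.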